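Fluoro in place of hydrogen: notes toward compound 4

The source may report more compounds than this note shows. Statements on the series, on what has been measured and on what is new or still open speak of the compounds shown alone.

Measured so far in a functional assay on HCT-116 cells (Homo sapiens) for inhibition, read by sulforhodamine B assay, with a stated time of 48 h, tested at 50 uM; on this read-out lower numbers stand for less inhibition of growth and higher numbers for more inhibition of growth at the one concentration tested:
compound 1 `O=C1C(=O)N(CCCCn2cc(COc3cc(=O)oc4ccccc34)nn2)c2ccccc21` gives 72%
compound 2 `O=C1C(=O)N(CCCn2cc(COc3cc(=O)oc4ccccc34)nn2)c2ccccc21` gives 79%
compound 3 `O=C1C(=O)N(CCCn2cc(COc3cc(=O)oc4ccccc34)nn2)c2ccc(F)cc21` gives 75%

The three measured values lie within the scatter of one another, so no order among them is claimed. Compound 4 `O=C1C(=O)N(CCCCn2cc(COc3cc(=O)oc4ccccc34)nn2)c2ccc(F)cc21` is not yet measured. It differs from compound 1 by fluoro in place of hydrogen on an aromatic carbon; the same change carries compound 2 to compound 3, (fluoro in place of hydrogen on an aromatic carbon), and in this assay that step is a number 4 percentage points lower from compound 2 to compound 3 (within the scatter). The difference between the two cores, that of compound 1 against that of compound 2, is not broken down here. The step to compound 4 is expected to be a number 4 percentage points lower from compound 1 to compound 4 (within the scatter), because the matched step a number 4 percentage points lower from compound 2 to compound 3 (within the scatter) stayed within the scatter. Compound 4 is therefore estimated at 68%, expected between 58% and 78%.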

Compound 4, percent growth inhibition at one concentration: 67%
Compound 4: the middle estimate sits 1 percentage points above what was measured; measured number inside the range.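

In this assay, fluoro in place of hydrogen on an aromatic carbon gives a number 5 percentage points lower from compound 1 to compound 4 (within the scatter). Set beside the earlier step, the change carries across the two cores without a detectable difference: the same change on two cores in this assay, a number 4 percentage points lower (within the scatter) from compound 2 to compound 3 and a number 5 percentage points lower (within the scatter) from compound 1 to compound 4, 1 percentage points apart, within the scatter of two such steps

Both steps lie within the scatter, so this does not show that fluoro alters growth inhibition on either core, and two cores give no basis for a rule across other cores.

Going by these compounds, whether chloro, methoxy or a nitrile on the same aromatic carbon would give a step beyond the scatter remains open. Also open, on these data alone, is what a longer chain than that of compound 1, or an amine on the chain, would do.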